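Notes on the step from compound 3 to compound 4

The source may report more compounds than this note shows. Statements on the series, on what has been measured and on what is new or still open speak of the compounds shown alone.

In a functional assay (strain AB) with Danio rerio as the target, read by microscopy, with a stated time of 1 h (a higher number here means that more compound is needed for the effect, a lower number that less compound is needed), compound 1 `CC(C)(C)OC(=O)CCCC[N+]1(C)CCc2c(sc(NC(=O)Nc3ccc(Cl)cc3)c2C(N)=O)C1` gives 140 nM. Compound 2 `CN1CCc2c(sc(NC(=O)Nc3ccc(Cl)cc3)c2C(N)=O)C1` gives 4700 nM. Compound 3 `NC(=O)c1c(NC(=O)Nc2ccc(Cl)cc2)sc2c1CCCC2` gives > 25000 nM, which is a limit and not a number. Compound 3 is the only one of the three at the limit of > 25000 nM in this assay, at which 1 of the 3 values shown sits.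

Compound 4 `C[N+]1(C2CCc3c(sc(NC(=O)Nc4ccc(Cl)cc4)c3C(N)=O)C2)CCC1` is reached from compound 3 by a group of 5 heavy atoms (4 carbon, 1 nitrogen; one four-membered non-aromatic ring with 1 hetero atom) in place of a hydrogen atom, on a saturated ring carbon. The entering group has a net charge of +1 and sits on a saturated ring carbon of the six-membered ring of carbon only.

Within the data shown here, no step between measured compounds is available, so the expectation rests on the values alone. Compound 1 also carries a net charge of +1, and its 140 nM supports an expectation of a measurable number for compound 4. Compound 2 has a nitrogen in the core without that charge, and its 4700 nM is also a measurable number. The group in compound 4 differs in place and shape from the chain in compound 1, so the range stays wide.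

In this assay the expected change is an at least 16-fold lower number from compound 3 to compound 4 (1.22 log units; beyond the scatter), a large step beyond the scatter, towards less compound needed.

For compound 4 the estimated value is 1500 nM, with an expected range from 200 nM to 12000 nM.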

Compound 4, half-maximal effective concentration: 3920 nM
Compound 4: the middle estimate sits 2.6-fold (0.42 log units) below what was measured, and the stated range covers the measured number.
By their numbers in this assay, from the lowest: compound 1; then compounds 4 and 2 (each within the scatter of the next). At a limit, above all of these: compound 3.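

Placing the group with one four-membered non-aromatic ring and a net charge of +1 on a saturated ring carbon of the six-membered ring of carbon only gives, in this assay, an at least 6.3-fold lower number from compound 3 to compound 4 (0.80 log units; beyond the scatter). Compound 3 stands at a limit of the assay and not at a number, so the size of this step is only a bound: the limit of > 25000 nM in this assay, at which 1 of the 4 values shown sits. This position therefore accepts the entering group with a measurable result, compound 4 giving 3920 nM, which compounds 1 to 3 could not show, as none of them carries a group on a saturated ring carbon of a ring of carbon only.

On these data alone, whether the step follows the net charge, the four-membered ring or simply the presence of any group on this carbon stays open. An uncharged dimethylamino group or a carboxylic acid on the same saturated ring carbon would bear on that question, as would a longer chain ending in a charged nitrogen.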